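This account rests on a few compounds, and the source may have more. Where it says the series, first, only, none or still open, it means among the compounds named here.

Series notes. Three compounds on the shared core have so far been run in a functional assay on COLO 205 cells (Homo sapiens) for inhibition, read by sulforhodamine B assay, with a stated time of 48 h; on this read-out lower numbers stand for higher toxicity in this test and higher numbers for lower toxicity in this test. Compound 1 `COc1cc(-c2nn(-c3cccc(NC(=O)c4ccc(Cl)c(C(F)(F)F)c4)c3)cc2-c2ccncc2)ccc1Cl` carries an amide bearing a 4-chloro-3-(trifluoromethyl)phenyl group; in this assay compound 1 returns only a limit, > 32500 nM, namely (the limit of > 32500 nM in this assay, at which 1 of the 3 values shown sits). Compound 2 `COc1cc(-c2nn(-c3cccc(NC(=O)c4cccc(C(F)(F)F)c4)c3)cc2-c2ccncc2)ccc1Cl` keeps the amide and gives 24800 nM in this assay. Compound 3 `COc1cc(-c2nn(-c3cccc(NC(=O)Nc4cccc(C(F)(F)F)c4)c3)cc2-c2ccncc2)ccc1Cl` turns the amide into a urea carrying a (3-(trifluoromethyl)phenyl)amino group and gives 3430 nM in this assay. Among the two plain numbers compound 3 stands lowest, with compound 2 nearest at a 7.2-fold lower number from compound 2 to compound 3 (0.86 log units; beyond the scatter); against compound 1 the urea stands apart at an at least 9.4-fold lower number from compound 1 to compound 3 (0.97 log units; beyond the scatter).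

Compound 4 `COc1cc(-c2nn(-c3cccc(NC(=O)Nc4ccc(Cl)c(C(F)(F)F)c4)c3)cc2-c2ccncc2)ccc1Cl` is the urea counterpart of compound 1. The change from compound 3 is chloro in place of hydrogen on an aromatic carbon. Among the measured compounds shown here, the one measured step touching the same change is the amide pair, where an at least 1.3-fold lower number from compound 1 to compound 2 (0.11 log units; that floor lies within the scatter). Read in reverse, chloro entering on the amide aryl gave only a limit, so its true size is open, but nothing there points to a large shift. For compound 4 a step of about a 1.5-fold higher number from compound 3 to compound 4 (0.16 log units; within the scatter) is therefore expected, a small rise in the number that may well sit within the scatter. Compound 4 is estimated at 5000 nM in this assay, with a range from 1800 nM to 14000 nM.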

Compound 4, concentration lethal to 50% of the cells: 3480 nM
For compound 4 the middle estimate is 1.4-fold (0.16 log units) above the measured one; the range from low to high includes it.
By their numbers in this assay, from the lowest: compounds 3 and 4 (each within the scatter of the next); then compound 2. At a limit, above all of these: compound 1.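

In this assay, chloro on the urea aryl ring, ortho to a trifluoromethyl group and para to a large group, now has a step read from two plain numbers, a 1.0-fold higher number from compound 3 to compound 4 (0.01 log units; within the scatter), so on the urea this change at this place shows no shift beyond the scatter. The urea also stands apart from the amide with chloro present on the urea aryl ring, as compound 3 alone could not show: a 7.1-fold lower number from compound 2 to compound 4 (0.85 log units; beyond the scatter), and an at least 9.3-fold lower number from compound 1 to compound 4 (0.97 log units; beyond the scatter). Compound 1 gives only a limit, so that last step is a floor, and the chloro change on the two cores reads as follows: the same change on two cores in this assay, an at least 1.3-fold lower number (0.11 log units; that floor lies within the scatter) from compound 1 to compound 2 and a 1.0-fold lower number (0.01 log units; within the scatter) from compound 4 to compound 3; the limit leaves it open whether they differ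

Still open, on these data alone, is whether a larger group at this place, such as methoxy, an amine or a carboxylic acid, would also stay within the scatter of compound 3. Also open, as far as these compounds go, is whether a nitrile in place of the trifluoromethyl, or a carbamate or a longer chain in place of the urea, would keep the lower numbers of compound 3 and compound 4.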